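Isopropyl amide in place of the methyloxazole amide

This account rests on a few compounds, and the source may have more. Where it says the series, first, only, none or still open, it means among the compounds named here.

The compounds share one core, an aminopyridine carrying an aryl group and an amide. In an assay on HEK293 cells for inhibition of sodium channel protein type 10 subunit alpha (Homo sapiens), read by fluorescence (a lower number here means a stronger inhibitor, a higher number a weaker inhibitor), compound 2 `COc1ccc(Cl)c(-c2ccc(NC(=O)c3conc3C)nc2N)c1` gives 500 nM, the lowest of the two numbers measured. Compound 3 `COc1ccc(Cl)cc1-c1ccc(NC(=O)c2ccnn2C)nc1N` gives 7400 nM in this assay, a gap from compound 2 that lies beyond the scatter. Compound 1 `CNC(=O)c1ccc(-c2cccc(Cl)c2)c(N)n1` reaches only a limit of this assay, > 32000 nM, and no number is known for it (the limit of > 32000 nM in this assay, at which 1 of the 3 values shown sits).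

Compound 4 `COc1ccc(Cl)c(-c2ccc(NC(=O)C(C)C)nc2N)c1` has not yet been measured. It differs from compound 2 in one place: isopropyl in place of 3-methyl-1,2-oxazol-4-yl on a carbonyl carbon. The amide substituent changes from an aromatic ring to a small branched chain, while the rest of the molecule, including the aryl group of compound 2, is kept. Among the measured compounds shown here, no step between measured compounds covers such a change, so the expectation rests on compound 2 alone. The writer expects a loss of potency beyond the scatter, the step from compound 2 to compound 4 being estimated as a 4.0-fold higher number from compound 2 to compound 4 (0.60 log units; beyond the scatter). Compound 4 is therefore expected to give about 2000 nM in this assay, with a range from 600 nM to 7000 nM.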

Compound 4, half-maximal inhibitory concentration: 4000 nM
Compound 4: middle estimate off by 2.0-fold (0.30 log units), on the low side; measured number inside the range.
By their numbers in this assay, from the lowest: compound 2; then compounds 4 and 3 (each within the scatter of the next). At a limit, above all of these: compound 1.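

With the aryl group held fixed, this step isolates the amide substituent: placing isopropyl in place of 3-methyl-1,2-oxazol-4-yl on a carbonyl carbon gives an 8.0-fold higher number from compound 2 to compound 4 (0.90 log units; beyond the scatter) in this assay and so shows that this position influences the number. The aromatic ring is not needed for a measurable value, since compound 4 gives 4000 nM in this assay. Nothing measured here bears on why the isopropyl group gives the higher number.

The compounds shown leave open whether the loss follows the removal of the ring or the removal of its oxygen and nitrogen atoms. A phenyl ring, a cyclopropyl group or a longer chain such as n-butyl on the same carbonyl carbon would help separate these possibilities.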